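The compounds below may be only part of what the source reports. "The series", "measured", "known", "first", "only" and "open" are said of these compounds alone.

Two quinolinol analogues built on the same core have been tested for their effect on leukaemia cells. Compound 1 `CC(C)CCOc1c(CCC(C)C)c(O)nc2ccccc12` carries an isopentyloxy group and an isopentyl chain, and in an ADME assay on CCRF-CEM cells (Homo sapiens) for cytotoxicity, read by MTT assay, with a stated time of 72 h (on this read-out higher numbers stand for lower toxicity in this test and lower numbers for higher toxicity in this test), compound 1 gives 160000 nM. Compound 2 `C#CCOc1c(CC#C)c(O)nc2ccccc12` carries a propargyloxy group and a propargyl group, and in this assay compound 2 gives 147000 nM. The two numbers lie within the scatter of one another, so compound 2 stands alongside compound 1 rather than apart from it; both values sit in a range that signals little cytotoxicity.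

Compound 3 `C#CCOc1cc(O)nc2ccccc12` differs from compound 2 by a single change, (hydrogen in place of propargyl on an aromatic carbon). Among the compounds with values here, no measured pair of compounds shows this change, so its effect is open. Given how close compound 1 and compound 2 lie, the change is not expected to move the number beyond the scatter in either direction, and the step of a 1.1-fold higher number from compound 2 to compound 3 (0.05 log units; within the scatter) is the estimate of that expectation. Compound 3 is therefore estimated to give 165000 nM in this assay, with a plausible range from 80000 nM to 340000 nM.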

Compound 3, half-maximal cytotoxic concentration: 103000 nM
For compound 3 the middle estimate is 1.6-fold (0.20 log units) above the measured one; the measured number falls inside the stated range.
By their numbers in this assay, from the lowest: compounds 3, 2 and 1 (each within the scatter of the next).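

Putting hydrogen in place of propargyl on this aromatic carbon, ortho to a hydroxy group and ortho to a propargyloxy group, gives a 1.4-fold lower number from compound 2 to compound 3 (0.15 log units; within the scatter) in this assay and so puts a first size on this change. In this one pair, the propargyl group can be taken off this carbon without the number leaving the scatter, so compound 3, with only hydrogen at this place, reads alongside compound 2 and not apart from it. Nothing measured here bears on why the step has this size.

One pair at one position leaves open whether another group on this carbon, such as an amine, a carboxylic acid or a longer chain, would carry the number beyond the scatter, or whether it would stay alongside compound 2 as compound 3 does. As far as these compounds go, it also remains open whether hydrogen in place of the isopentyl chain of compound 1 would give a similar step, and whether a change at the propargyloxy group would matter any more than this one did.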